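Distal carbamate removal in a melatonin receptor agonist series

The compounds below may be only part of what the source reports. "The series", "measured", "known", "first", "only" and "open" are said of these compounds alone.

Measured so far:
compound 1 `CCC(=O)NCCN(C)c1cccc(OCCCCCCNC(=O)Oc2cccc(-c3ccccc3)c2)c1` — 0.88
compound 2 `CC(=O)NCCN(C)c1cccc(OCCCCCCN)c1` — 0.08
compound 3 `CC(=O)NCCN(C)c1cccc(OCCCCCCOc2cccc(OC(=O)NC3CCCCC3)c2)c1` — 0.71

All three are compared in a functional assay on cells for agonist activity at melatonin receptor type 1B (Homo sapiens), read by GTPgammaS binding, with a stated time of 30 min; a lower number here means a smaller maximal response, a higher number a larger maximal response. Compound 3 gives 0.71 and stands second highest of the three numbers. Compound 1 is the nearest, with 0.88, a gap beyond the scatter; compound 2 is the furthest, with 0.08, far lower and well beyond the scatter. Within the data shown here, no single-point steps between measured compounds are available, so the bare amine of compound 2 and the carbamates of compounds 1 and 3 can only be set side by side, not resolved into separate changes.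

Compound 4 `CC(=O)NCCN(C)c1cccc(OCCCCCCOc2cccc(O)c2)c1` has not been measured. It differs from compound 3 in one place: hydrogen in place of cyclohexylcarbamoyl on an oxygen on an aromatic ring. The shared core and the six-carbon chain to the distal aromatic ring are retained; only the carbamate is stripped back to the phenol.

With the carbamate gone, a drop in maximal response is expected, clearly beyond the scatter, but not down to the level of compound 2 because compound 2 gives 0.08 without any distal ring: the expected step is a number 0.26 lower from compound 3 to compound 4 (beyond the scatter). For compound 4 in this assay the estimate is 0.45, with a range of 0.15 to 0.75.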

Compound 4, intrinsic activity: the largest response reached, as a fraction of the reference agonist's: 0.57
For compound 4 the middle estimate is 0.12 below the measured one; the range from low to high includes it.
By their numbers in this assay, from the lowest: compound 2; then compound 4; then compound 3; then compound 1.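

In this assay, the cyclohexylcarbamoyl on the oxygen on an aromatic ring proves not to be needed for most of the maximal response: cutting (cyclohexylcarbamoyl)oxy back to hydroxy gives a number 0.14 lower from compound 3 to compound 4 (beyond the scatter), a real but limited loss. Among these compounds, the first single-point step at the chain end, 3-hydroxyphenoxy in place of amino, gives a number 0.49 higher from compound 2 to compound 4 (beyond the scatter), so within this pair a substantial response is already present with the phenol, without any carbamate. No measurement shown offers an explanation for either step.

Open, from the compounds shown here alone, is what the remaining response requires at this site: whether the hydroxy itself counts, or whether a methoxy or an unsubstituted phenoxy end group would serve equally, and whether a smaller group such as methylcarbamoyl on the same oxygen would recover the response seen with cyclohexylcarbamoyl. Compound 1 differs from compound 3 and compound 4 in more than one place, so its higher response cannot be assigned to any single feature, and the effect of a shorter or longer chain on the phenol end also remains to be seen.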